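A few compounds are considered here, and "the series" means these few. Any claim that something is new, unique, unknown or untested is made for them only; others in the source may bear on it.

Measured so far:
compound 1 (`CC(C)C(NS(=O)(=O)c1ccc(F)cc1)C1=CC(=O)c2c(O)ccc(O)c2C1=O`) - "not determined" (no result reported)
compound 2 (`CC(=O)c1ccc(S(=O)(=O)NC(C2=CC(=O)c3c(O)ccc(O)c3C2=O)C(C)C)cc1`) - 110 nM

The series is read in a functional assay on HL-60 cells (Homo sapiens) for cytotoxicity, read by MTT assay (on this read-out lower numbers stand for stronger inhibition and higher numbers for weaker inhibition), and compound 1 stands there without a single number: the entry for compound 1 is "not determined" (no result reported), so it offers no starting level of its own. Among the compounds with values here, compound 2 gives 110 nM as the only measured number.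

The next compound to be read is compound 3 (`CC(NS(=O)(=O)c1ccc(F)cc1)C1=CC(=O)c2c(O)ccc(O)c2C1=O`). It has methyl in place of isopropyl on a saturated chain carbon bound to a double-bonded ring carbon and a sulfonamide nitrogen. Within the data shown here, the series holds no measured step for this change, so its size cannot be read from the data. In this assay the working expectation is a step from compound 1 to compound 3 no larger than the usual scatter, with neither direction favoured. Among the measured compounds shown here, the expected level rests on compound 2 at 110 nM as the only available number, and the range is kept wide for that reason.

Compound 3 is estimated at 200 nM, with an expected range of 60 nM to 700 nM in this read-out.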

Compound 3, half-maximal inhibitory concentration: 90 nM
Compound 3: the middle estimate sits 2.2-fold (0.35 log units) above what was measured, and the stated range covers the measured number.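

In this assay, within the data shown here, compound 1 stands at "not determined" (no result reported) while compound 3 gives 90 nM, so no step from compound 1 to compound 3 can be read. The compounds shown leave open how methyl in place of isopropyl shifts this read-out. No evidence on hand bears on the result.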